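Bromo to methoxy on an antiproliferative compound

The source may report more compounds than this note shows. Statements on the series, on what has been measured and on what is new or still open speak of the compounds shown alone.

In a functional assay on MCF7 cells (Homo sapiens) for antiproliferative activity, read by MTT assay, with a stated time of 24 h (a lower number here means a stronger inhibitor, a higher number a weaker inhibitor), compound 1 (`O=S(=O)(Nc1ccc2cc[nH]c2c1)c1ccc(Br)cc1`) gives 37800 nM and compound 2 (`O=C(Nc1ccc2cc[nH]c2c1)c1cccc(C(F)(F)F)c1`) gives 30600 nM as its value. For the measured compounds named here, these two numbers lie within the usual scatter of each other, so compound 1 stands level with the only other compound measured so far. Compound 3 (`COc1ccc(S(=O)(=O)Nc2ccc3cc[nH]c3c2)cc1`) has not yet been measured in this assay. It keeps the core of compound 1 and carries methoxy in place of bromo on an aromatic carbon, para to a large group (methoxy in place of bromo on an aromatic carbon). Going by the values given here, no measured step is available to show what such a change does, so the data offer no ground for expecting a large shift in either direction. The estimate therefore starts from compound 1 at 37800 nM as its reference point. The expected change is a 1.1-fold lower number from compound 1 to compound 3 (0.03 log units; within the scatter) and is not expected to exceed the scatter. For compound 3 the estimated value is 35000 nM with an expected range from 15000 nM to 80000 nM around it.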

Compound 3, half-maximal inhibitory concentration: 57200 nM
Compound 3: the middle estimate sits 1.6-fold (0.21 log units) below what was measured; measured number inside the range.
By their numbers in this assay, from the lowest: compounds 2, 1 and 3 (each within the scatter of the next).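

In this assay, for the compounds shown here, the exchange of bromo for methoxy on an aromatic carbon, para to a large group, gives the first measured step at this position: a 1.5-fold higher number from compound 1 to compound 3 (0.18 log units; within the scatter). The exchange puts two heavy atoms in place of one and brings in a hydrogen-bond acceptor where bromo counted none, yet the values of the two compounds cannot be told apart, so this single step shows no sensitivity of the number to this particular change. No measurement is at hand that bears on this result, and the values alone give no account of it.

At this position on the core of compound 1 only bromo and methoxy are shown, so it remains open whether an amine, a carboxylic acid or a longer chain there would give a step beyond the scatter. One step at one position also leaves open whether the same exchange elsewhere on this six-membered aromatic ring would read the same way.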